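This account rests on a few compounds, and the source may have more. Where it says the series, first, only, none or still open, it means among the compounds named here.

Compound 1 `CNC(=O)c1c(O)c2cccnc2n(-c2ccccc2)c1=O`, compound 2 `CCCCNC(=O)c1c(O)c2cccnc2n(-c2ccccc2)c1=O` and compound 3 `O=C(Nc1ccccc1)c1c(O)c2cccnc2n(-c2ccccc2)c1=O` share one core and differ only in the group on the amide-type nitrogen. In a functional assay on the whole organism for inhibition, with Rattus norvegicus as the target, read by paw edema, at a dose of 100 mg/kg by the oral route (on this read-out lower numbers stand for less inhibition and higher numbers for more inhibition at the one dose given (going by the name of the read-out)), compound 1 gives 9.6%, compound 2 gives 12.8%, and compound 3 gives 4.6%. Compound 3 carries the lowest of the three numbers, yet the gaps to its neighbours are small: a number 5 percentage points lower from compound 1 to compound 3 (within the scatter), and a number 8.2 percentage points lower from compound 2 to compound 3 (within the scatter). The swap at the same nitrogen between the two alkyl members, a number 3.2 percentage points higher from compound 1 to compound 2 (within the scatter), likewise stays within the scatter. Compound 4 `O=C(Nc1ccc(Cl)cc1)c1c(O)c2cccnc2n(-c2ccccc2)c1=O` keeps the anilino group of compound 3 and differs from it in one place: chloro in place of hydrogen on an aromatic carbon. For the measured compounds named here, none of the measured steps makes this kind of change on the aromatic ring; the nearest comparisons are the substitutions on the amide-type nitrogen, all of which moved the read-out by amounts within the scatter. The expected step for compound 4 is a number 1.4 percentage points higher from compound 3 to compound 4 (within the scatter), which amounts to no change beyond the scatter. Compound 4 in this assay is estimated at 6%, with a range from -5% to 18%.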

Compound 4, a percentage reported as inhibition, in the whole organism at one dose (the size of the read-out at that dose, not a potency): 11.6%
The estimate for compound 4 lay 5.6 percentage points below the measured number; the range from low to high includes it.
By their numbers in this assay, from the lowest: compounds 3, 1, 4 and 2 (each within the scatter of the next).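

Chloro in place of hydrogen on an aromatic carbon, para to a large group, is the first change on this ring among the compounds shown, and in this assay it gives a number 7 percentage points higher from compound 3 to compound 4 (within the scatter) and so no shift beyond the scatter. Set against the alkyl members, the 4-chlorophenyl group on the amide-type nitrogen gives a number 1.2 percentage points lower from compound 2 to compound 4 (within the scatter) and a number 2 percentage points higher from compound 1 to compound 4 (within the scatter) and thus leaves all four groups at that nitrogen within the scatter of one another. Nothing available here offers a reason for these numbers.

From the compounds shown here alone, whether a methoxy group, an amine or a carboxylic acid at this same place would move the read-out beyond the scatter stays open. Also open, going by these compounds, is what chloro would do on another carbon of this ring, or on the phenyl group of the shared core.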